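The source may report more compounds than this note shows. Statements on the series, on what has been measured and on what is new or still open speak of the compounds shown alone.

Measured compounds in the series:
- compound 1 `COc1cc(-c2cc(/C=C/C(=O)c3ccc(N)cc3)[nH]n2)cc(OC)c1OC` gives 7260 nM
- compound 2 `COc1cc(-c2cc(/C=C/C(=O)c3ccc(Cl)c(Cl)c3)[nH]n2)cc(OC)c1OC` gives > 100000 nM (a limit of the assay, not a number)
- compound 3 `COc1ccc(C(=O)/C=C/c2cc(-c3cc(OC)c(OC)c(OC)c3)n[nH]2)cc1` gives 7270 nM

In a functional assay on OVCAR-3 cells (Homo sapiens) for inhibition, read by sulforhodamine B assay, with a stated time of 48 h (a lower number here means that less compound is tolerated, a higher number that more compound is tolerated), compound 3 sits at the higher of the two numbers, with compound 1 nearest: the step of a 1.0-fold higher number from compound 1 to compound 3 (0.00 log units; within the scatter) lies within the scatter, so no order between them can be read. Compound 2 is reported only as a limit in this assay, (the limit of > 100000 nM in this assay, at which 1 of the 3 values shown sits).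

Compound 4 `COc1cc(-c2cc(/C=C/C(=O)c3ccc(F)c(F)c3)[nH]n2)cc(OC)c1OC` has not yet been measured. It differs from compound 3 in one place: 3,4-difluorophenyl in place of 4-methoxyphenyl on a carbonyl carbon.

Going by the values given here, two measured steps bear on this change, both swapping the aryl group on the carbonyl carbon. The step of an at least 13-fold lower number from compound 2 to compound 3 (1.13 log units; beyond the scatter) and the step of an at least 13-fold higher number from compound 1 to compound 2 (1.13 log units; beyond the scatter) show that the 3,4-dichlorophenyl sits far beyond the 4-methoxyphenyl and the 4-aminophenyl in this assay. The 3,4-difluorophenyl of compound 4 carries the same substitution pattern as the 3,4-dichlorophenyl, though with fluorine rather than chlorine, so a step upward from compound 3 beyond the scatter is expected, possibly smaller than the measured one.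

Compound 4 is therefore expected to give 30000 nM in this assay, within 8000 nM to 100000 nM, a step of a 4.1-fold higher number from compound 3 to compound 4 (0.62 log units; beyond the scatter).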

Compound 4, concentration lethal to 50% of the cells: 43600 nM
Estimate against measurement, compound 4: 1.5-fold (0.16 log units) below; low and high end bracket the measured number.
By their numbers in this assay, from the lowest: compounds 1 and 3 (each within the scatter of the next); then compound 4. At a limit, above all of these: compound 2.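

In this assay, the 3,4-difluorophenyl on the carbonyl carbon separates clearly from both groups that had given indistinguishable numbers, with the steps of a 6.0-fold higher number from compound 3 to compound 4 (0.78 log units; beyond the scatter) and a 6.0-fold higher number from compound 1 to compound 4 (0.78 log units; beyond the scatter). Among the compounds shown, a high number is therefore no longer tied to the 3,4-dichlorophenyl alone: both aryl groups bearing two halogens stand higher than the 4-methoxyphenyl and the 4-aminophenyl, and no compound here goes against this, while the choice of halogen also registers, with the step of an at least 2.2-fold lower number from compound 2 to compound 4 (0.36 log units; beyond the scatter). That last step is open-ended, since compound 2 is reported only as a limit of the assay, not as a number: the limit of > 100000 nM in this assay, at which 1 of the 4 values shown sits.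

How far fluorine and chlorine lie apart at this position therefore remains unresolved, and the four compounds do not show whether two halogens are needed or whether a single fluorine or an unsubstituted phenyl would also reach the higher range. Also open, as far as these compounds go, is where aryl groups carrying a trifluoromethyl, a nitrile or a carboxylic acid would fall in this assay, and whether the order seen here would hold on a different core.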